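Pyrimidinyl and aryl amines: removal of a pyrrolidinyl substituent

A few compounds are considered here, and "the series" means these few. Any claim that something is new, unique, unknown or untested is made for them only; others in the source may bear on it.

Measured so far in a functional assay on MDA-MB-231 cells for antagonist activity at C-X-C chemokine receptor type 4 (Homo sapiens), tested at 100 nM; on this read-out higher numbers stand for a stronger effect at the one concentration tested and lower numbers for a weaker effect:
- compound 1 `COc1ncc(F)c(NCc2ccc(CNc3nc(OC)ncc3F)cc2)n1` gives 100%
- compound 2 `c1cnc(NCc2ccc(CNc3ccccc3N3CCCC3)cc2)nc1` gives 73%
- compound 3 `Fc1cccc(NCc2ccc(CNc3cccc(F)n3)cc2)n1` gives 85%

Compound 2 stands lowest of the three numbers in this assay. The nearest is compound 3, whose number is higher by a margin beyond the scatter; the furthest is compound 1, higher still, also beyond the scatter. Compound 2 is the only one of the three that carries a carbon-only aromatic ring on one of the two amine arms, with a pyrrolidin-1-yl group on it; the other two carry heteroaromatic rings on both arms.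

Compound 4 `c1ccc(NCc2ccc(CNc3ncccn3)cc2)cc1` is not yet measured. It differs from compound 2 in one place: hydrogen in place of pyrrolidin-1-yl on an aromatic carbon. No step between measured compounds exists for this change, so its size cannot be read from the data shown. Compound 2 already sits lowest, and the change takes away a group without putting anything in its place. A step downward of moderate size is expected, a number 15 percentage points lower from compound 2 to compound 4 (beyond the scatter), though a result within the scatter of compound 2 would not be surprising. Compound 4 is therefore estimated at 58% in this assay, expected to fall between 30% and 82%.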

Compound 4, a percentage reported as inhibition, at one concentration (the size of the read-out at that concentration, not a potency): 100%
Compound 4: middle estimate off by 42 percentage points, on the low side; measured number outside the range, above it.
By their numbers in this assay, from the lowest: compound 2; then compound 3; then compounds 1 and 4 (each within the scatter of the next).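

Going from the pyrrolidin-1-yl group to hydrogen on this aromatic carbon, this assay shows a number 27 percentage points higher from compound 2 to compound 4 (beyond the scatter) and compound 4 gives 100% in this read-out, so the effect at the one concentration tested does not depend on the pyrrolidin-1-yl group at this place. Among the compounds shown here, this is the first step that isolates this position, and it shows that in this matched pair the unsubstituted six-membered aromatic ring of carbon only outperforms the ring carrying the pyrrolidin-1-yl group. The comparison holds for this pair only, and nothing shown here gives a reason for the rise.

Still open, on these data alone, is whether the step follows from the loss of the whole pyrrolidin-1-yl group or from its particular form, which a smaller azetidin-1-yl ring, an open dimethylamino group, a methoxy group or a single fluorine at the same carbon would help to separate. Also open, as far as these compounds go, is how far compound 2 and compound 4 differ in potency, since a read-out at one concentration gives the size of the effect there and not a full concentration-response measure.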